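Methoxy for Methylsulfonyl on the Quinolone Tetrazole Core

The compounds below may be only part of what the source reports. "The series", "measured", "known", "first", "only" and "open" are said of these compounds alone.

Measured compounds:
compound 1 `O=c1c(-c2nn[nH]n2)c[nH]c2ccccc12` with 1.25 mg/kg
compound 2 `CS(=O)(=O)c1cccc2c(=O)c(-c3nn[nH]n3)c[nH]c12` with 10 mg/kg

In a functional assay on the whole organism (strain Sprague-Dawley) for inhibition, with Rattus norvegicus as the target (on this read-out lower numbers stand for an effect already at smaller amounts and higher numbers for an effect only at larger amounts of compound), compound 2 gives 10 mg/kg, the highest of the two numbers; the nearest is compound 1, which gives 1.25 mg/kg. Compound 3 `COc1cccc2c(=O)c(-c3nn[nH]n3)c[nH]c12` is not yet measured. It differs from compound 2 by methoxy in place of methylsulfonyl on an aromatic carbon. Going by the values given here, only one step bears on this: an 8.0-fold higher number from compound 1 to compound 2 (0.90 log units; beyond the scatter). Among the compounds with values here, no measured pair shows what methoxy does at that carbon, so compound 3 is expected to fall between the two measured numbers, with a step of a 3.3-fold lower number from compound 2 to compound 3 (0.52 log units; beyond the scatter). The estimate for compound 3 is 3 mg/kg, within 1 mg/kg to 10 mg/kg.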

Compound 3, minimum effective dose: 0.15 mg/kg
Compound 3: middle estimate off by 20-fold (1.30 log units), on the high side, and the stated range ends above it.
By their numbers in this assay, from the lowest: compound 3; then compound 1; then compound 2.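

In this assay this aromatic carbon proves open to gain as well as loss, with a 67-fold lower number from compound 2 to compound 3 (1.82 log units; beyond the scatter) and with an 8.3-fold lower number from compound 1 to compound 3 (0.92 log units; beyond the scatter) on the same read-out. Substitution at this carbon therefore does not in itself raise the number, as compound 2 alone suggested; the outcome depends on which group sits there. No measurement at hand explains the difference between methoxy and methylsulfonyl. From the compounds shown here alone, how ethoxy, a hydroxyl group or an amine at this carbon would compare remains open, as does whether methoxy would give the same gain at other carbons of the shared core.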